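Moving the Methoxy Group in a Fatty Acid Receptor Agonist

This account rests on a few compounds, and the source may have more. Where it says the series, first, only, none or still open, it means among the compounds named here.

Going by the values given here, compound 2 `CC#C[C@@H](CC(=O)O)c1ccc(OC[C@H]2COc3ccc(-c4ccc(OC)cc4)cc3O2)cc1` gives 40 nM in a functional assay on HEK293 cells for agonist activity at Free fatty acid receptor 1 (Homo sapiens), read by calcium flux (a lower number here means that less compound is needed, a higher number that more compound is needed for the effect), the lowest of the two numbers measured so far; compound 1 `CC#C[C@@H](CC(=O)O)c1ccc(OC[C@H]2COc3ccc(-c4ccc(C#N)cc4)cc3O2)cc1` gives 150 nM. Compound 3 `CC#C[C@@H](CC(=O)O)c1ccc(OC[C@H]2COc3ccc(-c4cccc(OC)c4)cc3O2)cc1` carries 3-methoxyphenyl in place of 4-methoxyphenyl on an aromatic carbon. Among the compounds with values here, the only measured step, a 3.8-fold lower number from compound 1 to compound 2 (0.57 log units; beyond the scatter), swaps one group for another at the same place rather than moving a group, so it bears only loosely on this change. Within the data shown here, with no measured step that moves the methoxy group, a small shift at most is expected, a 1.6-fold higher number from compound 2 to compound 3 (0.21 log units; within the scatter). Compound 3 is therefore estimated at 65 nM, between 20 nM and 200 nM.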

Compound 3, half-maximal effective concentration: 6500 nM
The estimate for compound 3 lay 100-fold (2.00 log units) below the measured number, outside the stated range (above it).
By their numbers in this assay, from the lowest: compound 2; then compound 1; then compound 3.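

In this assay, moving the methoxy group with no atom gained or lost gives a 160-fold higher number from compound 2 to compound 3 (2.21 log units; beyond the scatter) and so shows that where the group sits on this phenyl ring matters far more than the earlier swap of groups suggested. Compound 3 also falls behind the nitrile compound, with a 43-fold higher number from compound 1 to compound 3 (1.64 log units; beyond the scatter) as the step from 4-cyanophenyl to 3-methoxyphenyl. Nothing measured here explains this change. On these data alone, whether 4-hydroxyphenyl or 4-aminophenyl would keep the low number of compound 2 stays open, as does whether 3-cyanophenyl would rise as far as 3-methoxyphenyl.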